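Moving the nitro group around the ring in a nucleotide series

The source may report more compounds than this note shows. Statements on the series, on what has been measured and on what is new or still open speak of the compounds shown alone.

Compound 1 `O=c1[nH]/c(=N\OCCCc2cccc(F)c2)ccn1[C@@H]1O[C@H](COP(=O)(O)OP(=O)(O)OP(=O)(O)O)[C@@H](O)[C@H]1O` gives 539 nM in a functional assay on 1321-N1 cells for agonist activity at P2Y purinoceptor 6 (Homo sapiens), read by scintillation counting and inositol phosphate accumulation; a lower number here means that less compound is needed, a higher number that more compound is needed for the effect. Compound 2 `O=c1[nH]/c(=N\OCCCc2ccc(F)cc2)ccn1[C@@H]1O[C@H](COP(=O)(O)OP(=O)(O)OP(=O)(O)O)[C@@H](O)[C@H]1O` gives 1210 nM in this assay. Compound 3 `O=c1[nH]/c(=N\OCCCc2cccc([N+](=O)[O-])c2)ccn1[C@@H]1O[C@H](COP(=O)(O)OP(=O)(O)OP(=O)(O)O)[C@@H](O)[C@H]1O` gives 9700 nM in this assay.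

Compound 3 stands at the highest number of the three. The step from compound 2 was an 8.0-fold higher number from compound 2 to compound 3 (0.90 log units; beyond the scatter), and the step from compound 1 was an 18-fold higher number from compound 1 to compound 3 (1.26 log units; beyond the scatter).

Compound 4 `O=c1[nH]/c(=N\OCCCc2ccc([N+](=O)[O-])cc2)ccn1[C@@H]1O[C@H](COP(=O)(O)OP(=O)(O)OP(=O)(O)O)[C@@H](O)[C@H]1O` is not yet measured. It differs from compound 3 in one place: 4-nitrophenyl in place of 3-nitrophenyl on a saturated chain carbon, three bonds along the chain from an oxygen. Among the compounds with values here, the one measured step that bears on this change is the move of fluoro from the 3-position to the 4-position of the same ring, which gave a 2.2-fold higher number from compound 1 to compound 2 (0.35 log units; beyond the scatter). Whether the nitro group behaves like fluoro when moved the same way is not shown by any other pair here, so the expectation rests on that single step.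

For compound 4, a modest rise in number beyond the scatter is expected, about a 2.1-fold higher number from compound 3 to compound 4 (0.31 log units; beyond the scatter), which puts the estimate at 20000 nM with a range from 6000 nM to 60000 nM.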

Compound 4, half-maximal effective concentration: 1330 nM
Beside the measured number, compound 4's estimate is 15-fold (1.18 log units) above it; measured number outside the range, below it.
By their numbers in this assay, from the lowest: compound 1; then compounds 2 and 4 (each within the scatter of the next); then compound 3.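

In this assay, moving a group around the ring does not have one fixed effect: going from 3-nitrophenyl to 4-nitrophenyl gave a 7.3-fold lower number from compound 3 to compound 4 (0.86 log units; beyond the scatter), while the matching fluoro move went the opposite way, with a 2.2-fold higher number from compound 1 to compound 2 (0.35 log units; beyond the scatter). The 4-nitrophenyl group is on a par with 4-fluorophenyl, at a 1.1-fold higher number from compound 2 to compound 4 (0.04 log units; within the scatter), yet it does not reach 3-fluorophenyl, at a 2.5-fold higher number from compound 1 to compound 4 (0.39 log units; beyond the scatter). Nitro in place of fluoro is therefore not a change of one size, and what it does depends on where the group sits on the ring: the same change on two cores in this assay, an 18-fold higher number (1.26 log units; beyond the scatter) from compound 1 to compound 3 and a 1.1-fold higher number (0.04 log units; within the scatter) from compound 2 to compound 4, 16-fold (1.21 log units) apart, beyond the scatter of two such steps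

Going by these compounds, it remains open whether another ring group, such as an amine or a carboxylic acid, would follow the fluoro pattern or the nitro pattern. Also open, on these data alone, is whether a longer chain would preserve the difference between the two ring placements.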